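Replacing a Dihydroxy Chain End With a Nitrile

The source may report more compounds than this note shows. Statements on the series, on what has been measured and on what is new or still open speak of the compounds shown alone.

Of the compounds shown here, three that share a core have been tested in a functional assay on Raji cells (Homo sapiens) for cytotoxicity, with a stated time of 72 h; a higher number here means that more compound is needed for the effect, a lower number that less compound is needed: compound 1 (`C=C[C@@](C)(/C=C/c1ccc(OS(=O)(=O)c2ccc(C)cc2)cc1)CCC=C(C)C`), compound 2 (`C=C[C@@](C)(/C=C/c1ccc(O)cc1)CCC(O)C(C)(C)O`) and compound 3 (`C=C[C@@](C)(/C=C/c1ccc(O)cc1)CC/C=C/C(=O)OCc1ccccc1`). Compound 1 gives > 26000 nM, which is a limit of the assay and not a number. Compound 2 gives > 26000 nM, which is again only a limit. Compound 3 gives > 26000 nM, and this too is a limit. Compound 2 therefore has no number of its own, and no order can be read among the three: the data show (the limit of > 26000 nM in this assay, at which 3 of the 3 values shown sit).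

Compound 4 (`C=C[C@@](C)(/C=C/c1ccc(O)cc1)CC/C=C/C#N`) has not yet been measured. Its structure differs from that of compound 2 by 2-cyanoethenyl in place of 1,2-dihydroxy-2-methylpropyl on a saturated chain carbon, three bonds along the chain from two double-bonded chain carbons.

Among the measured compounds shown here, no measured pair differs in just one place, so no measured step can guide the size of this one. For the measured compounds named here, the only anchor is compound 2 at > 26000 nM, a limit. The expected size of an at least 1.0-fold lower number from compound 2 to compound 4 (0.03 log units; that floor lies within the scatter) lies within the usual scatter, with no direction favoured. Compound 4 may well be reported only as a limit too. If a number is obtained, the estimated value for compound 4 is 24000 nM, with an expected range from 9000 nM to 50000 nM.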

Compound 4, half-maximal effective concentration: > 26000 nM
Compound 4 was reported as a limit; the forecaster's own chance of this, stated with the estimate: 70%; at least 1.0-fold (0.03 log units) between middle value and limit.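

Compound 4 gives > 26000 nM, which is a limit of the assay and not a number. Compound 2 also stands only at a limit, so no step can be read between compound 2 and compound 4: the limit of > 26000 nM in this assay, at which 4 of the 4 values shown sit.

On these data alone, it stays open how 2-cyanoethenyl and 1,2-dihydroxy-2-methylpropyl compare, and whether any of the four compounds would give an actual number in this assay.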